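The source may hold more compounds than are shown below. What is called first, only, known or untested is meant among the compounds shown, and "the series" means these compounds.

In an assay on membranes from Sf9 cells for displacement of a labelled ligand from histamine H2 receptor (Homo sapiens), read by scintillation counting, with a stated time of 60 min (a higher number here means a weaker inhibitor, a lower number a stronger inhibitor), compound 1 `N/C(=N\C(=O)NC1CCCCC1)Nc1cccc(-c2csc(N)n2)c1` gives 4470 nM. Compound 2 `Cc1nc(N)sc1CCCN/C(N)=N/C(=O)NCc1ccco1` gives 10.5 nM in this assay, the lowest of the two numbers shown, and its gap to compound 1 lies well beyond the scatter. Compound 3 `Cc1nc(N)sc1CCCN/C(N)=N/C(=O)NC(C)c1ccco1` has not yet been measured; it differs from compound 2 by methyl in place of hydrogen on a saturated chain carbon bound to an amide-type nitrogen and an aromatic carbon. Among the compounds with values here, no pair of measured compounds differs in a single place, so the size of such a step is untested. In this assay the step of a 1.5-fold higher number from compound 2 to compound 3 (0.18 log units; within the scatter) is expected to be small, most likely within the scatter or at most a slight weakening. Compound 3 is therefore estimated at 16 nM, with a range of 5 nM to 50 nM.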

Compound 3, inhibition constant: 31.6 nM
Compound 3: middle estimate off by 2.0-fold (0.30 log units), on the low side, and the stated range covers the measured number.
By their numbers in this assay, from the lowest: compound 2; then compound 3; then compound 1.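

In this assay, the series gains its first single-place step, with methyl in place of hydrogen on the saturated chain carbon bound to an amide-type nitrogen and an aromatic carbon giving a 3.0-fold higher number from compound 2 to compound 3 (0.48 log units; beyond the scatter). This position is therefore sensitive to the added methyl, although the loss is modest and potency remains measurable in the same assay. Nothing available explains the size of this step. Still open, on these data alone, is how an ethyl or a second methyl on this carbon would read. Also open, as far as these compounds go, is whether the methyl step holds when phenyl replaces the furan-2-yl group.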